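Chloro for methoxy on the thiazole-side aryl ring

The source may hold more compounds than are shown below. What is called first, only, known or untested is meant among the compounds shown, and "the series" means these compounds.

Measured compounds:
compound 1 `COc1ccc(-c2nc(C)c(C(=O)CSc3nc(N)c(C#N)c(-c4ccc(Cl)cc4)n3)s2)cc1` gives 44%
compound 2 `COc1ccc(-c2nc(C)c(C(=O)CSc3nc(N)c(C#N)c(-c4ccccc4)n3)s2)cc1` gives 57.8%
compound 3 `COc1ccc(-c2nc(C)c(C(=O)CSc3nc(N)c(C#N)c(-c4ccc(OC)cc4)n3)s2)cc1` gives 28.7%

The read-out is a functional assay on U-87MG ATCC cells for antiproliferative activity against U-87 MG (Homo sapiens), read by MTT assay, with a stated time of 48 h, tested at 10 uM; a higher number here means a weaker effect of the compound at the concentration tested, a lower number a stronger effect. Among the three numbers, compound 1 stands second highest: the nearest is compound 2, which lies higher a number 13.8 percentage points higher from compound 1 to compound 2 (beyond the scatter), and the furthest is compound 3, which lies lower a number 15.3 percentage points lower from compound 1 to compound 3 (beyond the scatter); between the other two the step runs a number 29.1 percentage points lower from compound 2 to compound 3 (beyond the scatter). All three measured steps concern the aryl ring on the aminopyrimidine side. Compound 4 `Cc1nc(-c2ccc(Cl)cc2)sc1C(=O)CSc1nc(N)c(C#N)c(-c2ccc(Cl)cc2)n1` differs from compound 1 elsewhere: chloro in place of methoxy on an aromatic carbon. Going by the values given here, no measured step touches this ring, so the only guide is that the corresponding exchange on the other ring, from compound 1 to compound 3, moved the number a number 15.3 percentage points lower from compound 1 to compound 3 (beyond the scatter), with methoxy giving the lower value. By that analogy compound 4 is expected to read somewhat higher than compound 1, a step of a number 8 percentage points higher from compound 1 to compound 4 (within the scatter), though a step within the scatter would not surprise. Compound 4 is therefore estimated at 52%, in the range 32% to 72%.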

Compound 4, a percentage reported as activity, at one concentration (the size of the read-out at that concentration, not a potency): 37.3%
Estimate against measurement, compound 4: 14.7 percentage points above; measured number inside the range.
By their numbers in this assay, from the lowest: compounds 3, 4 and 1 (each within the scatter of the next, the first and the last beyond it); then compound 2.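

In this assay, going by these compounds alone, the exchange of 4-methoxyphenyl for 4-chlorophenyl gives a number 6.7 percentage points lower from compound 1 to compound 4 (within the scatter) and is the first evidence on this ring, where chloro stands in place of methoxy without a change that can be told from the scatter. On the other aryl ring, the corresponding exchange gives a number 15.3 percentage points lower from compound 1 to compound 3 (beyond the scatter) in the opposite direction of replacement, so within these compounds the two rings do not respond alike to this pair of groups. No measured evidence available here explains this difference.

Going by these compounds, whether this position stays as unresponsive with a hydrogen, an amine or a carboxylic acid in place of methoxy remains open. On these data alone, it is also open whether chloro and methoxy would stay within the scatter of each other here with a different group on the other aryl ring.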